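Nitrile to Methoxy on the Ring at the Aromatic Nitrogen

A few compounds are considered here, and "the series" means these few. Any claim that something is new, unique, unknown or untested is made for them only; others in the source may bear on it.

Three compounds share one core and differ only in the six-membered aromatic ring of carbon only that sits on an aromatic nitrogen. Compound 1 `CC1(C)[C@H]2CC[C@]1(C)N(Cc1cn(-c3cccc(C#N)c3)nn1)C(=O)C2` gives 260 nM in a functional assay on PANC-1 cells (Homo sapiens) for inhibition, read by MTT assay, with a stated time of 24 h (a higher number here means a weaker inhibitor, a lower number a stronger inhibitor), the highest of the three numbers, yet each neighbour lies within the scatter: compound 2 `CC1(C)[C@H]2CC[C@]1(C)N(Cc1cn(-c3ccccc3F)nn1)C(=O)C2` gives 150 nM and compound 3 `CC1(C)[C@H]2CC[C@]1(C)N(Cc1cn(-c3ccccc3O)nn1)C(=O)C2` gives 230 nM. Compound 4 `COc1cccc(-n2cc(CN3C(=O)C[C@@H]4CC[C@@]3(C)C4(C)C)nn2)c1` is not yet measured; it differs from compound 1 by methoxy in place of cyano on an aromatic carbon. Within the data shown here, the steps that bear on this, a 1.7-fold lower number from compound 1 to compound 2 (0.24 log units; within the scatter) and a 1.1-fold lower number from compound 1 to compound 3 (0.05 log units; within the scatter), both alter the same ring and both stay within the scatter. A further change on that ring is therefore expected to move the number little, if at all: a 1.0-fold lower number from compound 1 to compound 4 (0.02 log units; within the scatter). Compound 4 is estimated at 250 nM, with a range from 120 nM to 520 nM.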

Compound 4, half-maximal inhibitory concentration: 860 nM
Beside the measured number, compound 4's estimate is 3.4-fold (0.54 log units) below it; the whole stated range lies below it.
By their numbers in this assay, from the lowest: compounds 2, 3 and 1 (each within the scatter of the next); then compound 4.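

Among these compounds, the ring on the aromatic nitrogen is less tolerant than compounds 1, 2 and 3 suggested, since 3-methoxyphenyl gives the first steps here beyond the scatter. In this assay there is a 3.3-fold higher number from compound 1 to compound 4 (0.52 log units; beyond the scatter) for the swap of cyano for methoxy at one place, and the other two comparisons agree, with a 3.7-fold higher number from compound 3 to compound 4 (0.57 log units; beyond the scatter) and a 5.7-fold higher number from compound 2 to compound 4 (0.76 log units; beyond the scatter) on this ring. Nothing shown here explains this change. Still open, from the compounds shown here alone, is whether methoxy alone weakens compounds at this place, or whether an amine or a longer ethoxy chain on the same carbon would do the same.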